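The compounds below may be only part of what the source reports. "The series", "measured", "known", "first", "only" and "open" are said of these compounds alone.

Measured compounds:
compound 1 `CSc1ccc(F)cc1NCC1=NCCN1` — 92%
compound 2 `CSc1cc(F)ccc1NCC1=NCCN1` — 78%

Of the compounds shown here, two built on the same core have so far been measured in a functional assay for agonist activity at Alpha-1B adrenergic receptor (Homo sapiens); a lower number here means a smaller maximal response, a higher number a larger maximal response. Compound 1 gives 92% in this assay, the higher of the two numbers. Compound 2 gives 78% in this assay, and the gap between compound 2 and compound 1 lies beyond the usual scatter of this kind of measurement. Within the data shown here, no step between two measured compounds that differ in a single place is available, so the effect of any one change on the maximal response cannot be read from the data.

Compound 3 `CSc1ccc(C(F)(F)F)cc1NCC1=NCCN1` has not been measured. It differs from compound 1 in one place: trifluoromethyl in place of fluoro on an aromatic carbon. Among the measured compounds shown here, with no comparable step on record, the expectation for compound 3 rests on the value of compound 1 and on the size of the group that enters. A modest decrease in this assay is expected, with the step estimated as a number 12 percentage points lower from compound 1 to compound 3 (beyond the scatter). Compound 3 is accordingly expected to reach about 80% in this assay, within a range from 55% to 100%.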

Compound 3, largest response reached (reported as maximum), in percent of the reference or control that the assay uses: 114%
The estimate for compound 3 lay 34 percentage points below the measured number; measured number above the stated range.
By their numbers in this assay, from the lowest: compound 2; then compound 1; then compound 3.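

In this assay, among these compounds, the exchange of fluoro for trifluoromethyl, on the aromatic carbon para to the methylsulfanyl group, provides the first step between compounds that differ in a single place: a number 22 percentage points higher from compound 1 to compound 3 (beyond the scatter). The entering group has 4 heavy atoms against 1 for the group that leaves, so this position accepts the larger group with a gain in maximal response rather than a loss, and compound 3 gives 114%, which lies above the response of the reference or control used in the assay. The data shown offer no measurement that could explain the rise at this carbon.

Among the compounds shown here, with only one step at this position, it remains open whether the gain follows from the number of heavy atoms or is particular to trifluoromethyl, a question that a methyl group, a chlorine atom, a nitrile or an amine on the same carbon would help to settle. As far as these compounds go, it also remains open how trifluoromethyl would behave on the carbon that carries fluoro in compound 2.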